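Swapping the Anilide Halogen in a Quinazoline Thioether Series

The source may report more compounds than this note shows. Statements on the series, on what has been measured and on what is new or still open speak of the compounds shown alone.

Measured so far:
- compound 1, `O=C(CSc1nc(Nc2ccccc2)c2ccccc2n1)Nc1cccc(Cl)c1`: 14300 nM
- compound 2, `O=C(CSc1nc(Nc2ccccc2)c2ccccc2n1)Nc1cccc(Br)c1`: 9620 nM

In a functional assay on MGC-803 cells (Homo sapiens) for inhibition, read by MTT assay, with a stated time of 72 h (on this read-out lower numbers stand for stronger inhibition and higher numbers for weaker inhibition), compound 1 gives 14300 nM, the highest of the two numbers. Compound 2 gives 9620 nM in this assay, and the change from compound 1 to compound 2 (a 1.5-fold lower number from compound 1 to compound 2 (0.17 log units; within the scatter)) shows that exchanging one halogen for another on that ring made no difference that can be trusted.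

Compound 3, `O=C(CSc1nc(Nc2ccccc2)c2ccccc2n1)Nc1ccc(F)cc1`, is not yet measured. It differs from compound 1 by 4-fluorophenyl in place of 3-chlorophenyl on an amide-type nitrogen: both the halogen and its position on the ring change at once. Among the compounds with values here, only the step from compound 1 to compound 2 bears on this, and it stayed within the scatter, so no step beyond the scatter is expected in this assay from compound 1 to compound 3 (a 1.1-fold higher number from compound 1 to compound 3 (0.05 log units; within the scatter)). Compound 3 is therefore estimated at 16000 nM, with a plausible range from 6000 nM to 45000 nM.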

Compound 3, half-maximal inhibitory concentration: > 50000 nM
Compound 3 ended at the assay's limit; the forecaster's own chance of this, stated with the estimate: 10%; middle value at least 3.1-fold (0.49 log units) from the limit.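

Placing 4-fluorophenyl on the amide-type nitrogen gives an at least 3.4-fold higher number from compound 1 to compound 3 (0.54 log units; beyond the scatter) and an at least 5.1-fold higher number from compound 2 to compound 3 (0.71 log units; beyond the scatter), both beyond the scatter. This shows that inhibition in this assay can respond to a change in the aryl group at this position, which the exchange of chloro for bromo alone did not reveal. The reading for compound 3 is a limit and not a number, so each step has a lower bound only: the limit of > 50000 nM in this assay, at which 1 of the 3 values shown sits.

The halogen and its place on the ring change together in compound 3, and the compounds shown do not tell which of the two carries the step; 3-fluorophenyl or 4-chlorophenyl on the same nitrogen would separate them. On these data alone, how a ring bearing a methoxy group or an amine would read also stays open.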